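Capping the Hydroxy Group of Compound 1 with a Sulfonyl

The source may hold more compounds than are shown below. What is called first, only, known or untested is meant among the compounds shown, and "the series" means these compounds.

Compound 1 `Cc1c(O)ccc2c1[C@H](Cn1cc(-c3ccccn3)nn1)[C@@]13CC(=O)[C@@](C)(CC[C@@H]21)C3`: > 20000 nM
Compound 2 `Cc1ccc(-c2cn(C[C@H]3c4c(ccc(O)c4C)[C@@H]4CC[C@@]5(C)C[C@]43CC5=O)nn2)cc1`: > 20000 nM
Compound 3 `Cc1c(O)ccc2c1[C@H](Cn1cc(-c3ccc(C(F)(F)F)cc3)nn1)[C@@]13CC(=O)[C@@](C)(CC[C@@H]21)C3`: > 20000 nM

In a functional assay on A549 cells (Homo sapiens) for cytotoxicity, read by MTT assay, with a stated time of 4 days (a lower number here means a stronger inhibitor, a higher number a weaker inhibitor), compound 1 gives only a limit of the assay, not a number, as shown by the limit of > 20000 nM in this assay, at which 3 of the 3 values shown sit. Compound 2 likewise returns only a limit. Compound 3 also returns only a limit. The steps a step that the two limits leave unreadable from compound 1 to compound 2 and a step that the two limits leave unreadable from compound 1 to compound 3 therefore cannot be sized, and a step that the two limits leave unreadable from compound 2 to compound 3 cannot be sized either. Compound 4 `Cc1ccc(S(=O)(=O)Oc2ccc3c(c2C)[C@H](Cn2cc(-c4ccccn4)nn2)[C@@]24CC(=O)[C@@](C)(CC[C@@H]32)C4)cc1` differs from compound 1 by (4-methylphenyl)sulfonyl in place of hydrogen on an oxygen on an aromatic ring. Within the data shown here, none of the measured steps touches this oxygen, and none carries a readable size, so no direction beyond the usual scatter can be expected; compound 4 is expected to stay near the limit. Compound 4 is estimated at 25000 nM, ranging from 5000 nM to 100000 nM. The expected step is a step that the limit leaves unreadable from compound 1 to compound 4.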

Compound 4, half-maximal inhibitory concentration: > 20000 nM
Compound 4 gave a limit, no number (the forecaster's own chance of this, stated with the estimate: 80%); the middle value lies beyond the limit too.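

Among these compounds, compound 4, like compound 1, returns only a limit, so no step between them can be read: the limit of > 20000 nM in this assay, at which 4 of the 4 values shown sit. The compounds shown leave open whether the (4-methylphenyl)sulfonyl on this oxygen changes cytotoxicity at all in this assay.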